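A few compounds are considered here, and "the series" means these few. Any claim that something is new, unique, unknown or untested is made for them only; others in the source may bear on it.

Compound 2, `COc1ccccc1N1CCN(CCn2c(=O)[nH]c3cc(-c4ccccc4Cl)[nH]c3c2=O)CC1`, is the point of departure. In an assay for binding affinity to Adrenergic receptor alpha-1 (Rattus norvegicus) (a higher number here means a weaker inhibitor, a lower number a stronger inhibitor), compound 2 gives 0.76 nM. Among the measured compounds shown here, its only measured neighbour is compound 1, `COc1ccccc1N1CCN(CCn2c(=O)[nH]c3cc(-c4ccccc4)[nH]c3c2=O)CC1`, which in this assay gives 0.52 nM. For the measured compounds named here, the one step that has been measured so far, a 1.5-fold higher number from compound 1 to compound 2 (0.16 log units; within the scatter), is therefore small, and compound 2 holds the higher of the two numbers without standing apart from compound 1 beyond the usual scatter.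

The next compound, compound 3, is `COc1ccccc1N1CCN(CCn2c(=O)[nH]c3cc(-c4ccc(Cl)cc4)[nH]c3c2=O)CC1`. It differs from compound 2 in this way: 4-chlorophenyl in place of 2-chlorophenyl on an aromatic carbon. The two compounds share every atom and differ only in where the chlorine sits on the phenyl ring.

Going by the values given here, only one measured step bears on this change, and only loosely: the step from compound 1 to compound 2 concerns putting a chlorine onto the phenyl ring, not moving it, and it stayed within the scatter. Among the compounds with values here, no measured step shows what moving the chlorine does. The expectation for compound 3 is therefore a step of a 1.1-fold higher number from compound 2 to compound 3 (0.02 log units; within the scatter), nothing beyond the scatter in either direction. Compound 3 is estimated at 0.8 nM, with a range from 0.3 nM to 2.2 nM.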

Compound 3, inhibition constant: 7.68 nM
Compound 3: middle estimate off by 9.6-fold (0.98 log units), on the low side, and the stated range ends below it.
By their numbers in this assay, from the lowest: compounds 1 and 2 (each within the scatter of the next); then compound 3.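

In this assay, among the compounds shown here, the position of the chlorine on the phenyl ring proves to matter, which the earlier compounds could not show: the earlier step, a 1.5-fold higher number from compound 1 to compound 2 (0.16 log units; within the scatter), stayed within the scatter, while moving the chlorine gives a 10-fold higher number from compound 2 to compound 3 (1.00 log units; beyond the scatter), a step beyond it. Measured against the unsubstituted phenyl, the 4-chlorophenyl group gives a 15-fold higher number from compound 1 to compound 3 (1.17 log units; beyond the scatter), so on this aromatic carbon, next to the ring nitrogen, adding a chlorine can leave the number within the scatter or raise it well beyond, depending only on where the chlorine sits on the phenyl ring, and compound 3 is the weakest of the three. Nothing available accounts for this gap between two compounds that have the same atoms.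

The compounds shown leave open whether the rise belongs to chlorine in particular or to any group at that place on the phenyl ring, as a fluoro, methyl or methoxy group in its stead would tell. They also leave open how a more distinct group there, such as an amine or a carboxylic acid, would read in this assay.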